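From a methylphenyl to a chlorophenyl on the ring nitrogen

The source may hold more compounds than are shown below. What is called first, only, known or untested is meant among the compounds shown, and "the series" means these compounds.

Three compounds share one core and differ only in the group on an amide-type nitrogen in a ring. Compound 1 `CC(C)CN1CC(c2nc(-c3cccc(Cl)c3)no2)CC1=O` carries isobutyl there and gives 920 nM in an in vitro functional assay on HEK293-A cells for negative allosteric modulation of metabotropic glutamate receptor 5 (Homo sapiens), read by FLIPR and calcium flux; on this read-out higher numbers stand for weaker inhibition and lower numbers for stronger inhibition. Compound 2 `Cc1ccc(N2CC(c3nc(-c4cccc(Cl)c4)no3)CC2=O)cc1` carries 4-methylphenyl; in this assay compound 2 reaches only > 10000 nM, which is a limit of the assay and not a number (the limit of > 10000 nM in this assay, at which 1 of the 3 values shown sits). Compound 3 `Cc1ccccc1N1CC(c2nc(-c3cccc(Cl)c3)no2)CC1=O` carries 2-methylphenyl and gives 370 nM in this assay. The measured steps are an at least 10-fold higher number from compound 1 to compound 2 (1.03 log units; beyond the scatter), a 2.5-fold lower number from compound 1 to compound 3 (0.40 log units; beyond the scatter) and an at least 27-fold lower number from compound 2 to compound 3 (1.43 log units; beyond the scatter). Of the two numbers, compound 3 stands lowest, and the nearest number, that of compound 1, lies above it by a 2.5-fold lower number from compound 1 to compound 3 (0.40 log units; beyond the scatter).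

Compound 4 `O=C1CC(c2nc(-c3cccc(Cl)c3)no2)CN1c1cccc(Cl)c1` has not been measured. Its change from compound 3 is 3-chlorophenyl in place of 2-methylphenyl on an amide-type nitrogen in a ring. Among the measured compounds shown here, the steps that bear on it are an at least 27-fold lower number from compound 2 to compound 3 (1.43 log units; beyond the scatter) and a 2.5-fold lower number from compound 1 to compound 3 (0.40 log units; beyond the scatter), both changes of the group on the same nitrogen, and they show that moving from one methylphenyl to the other shifts the number greatly. The 3-chlorophenyl of compound 4 matches neither measured aryl group, so the expectation is wide. Compound 4 is expected to give 1500 nM, estimated between 400 nM and 6000 nM. That estimate means a 4.1-fold higher number from compound 3 to compound 4 (0.61 log units; beyond the scatter), an expected weakening that remains uncertain.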

Compound 4, half-maximal inhibitory concentration: 1100 nM
Compound 4: middle estimate off by 1.4-fold (0.13 log units), on the high side; the range from low to high includes it.
By their numbers in this assay, from the lowest: compound 3; then compounds 1 and 4 (each within the scatter of the next). At a limit, above all of these: compound 2.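

Among the compounds shown here, compound 4 shows that 2-methylphenyl is not the only aryl group on this amide-type nitrogen that gives a measured number in this assay, with an at least 9.0-fold lower number from compound 2 to compound 4 (0.95 log units; beyond the scatter). Compound 2 stands at a limit of the assay and not at a number: the limit of > 10000 nM in this assay, at which 1 of the 4 values shown sits. The swap of 2-methylphenyl for 3-chlorophenyl, two groups that both hold 7 heavy atoms and one six-membered aromatic ring, still gives a 3.0-fold higher number from compound 3 to compound 4 (0.47 log units; beyond the scatter), so compound 3 remains the strongest of the four, while the step between the isobutyl and 3-chlorophenyl groups, a 1.2-fold higher number from compound 1 to compound 4 (0.08 log units; within the scatter), does not separate them.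

On these data alone, it stays open whether the difference between the 2-methylphenyl and 3-chlorophenyl groups follows from chlorine taking the place of methyl or from the different numbered place on the phenyl ring, and 3-methylphenyl and 2-chlorophenyl on the same nitrogen would pull those two apart. The compounds shown also say nothing about an unsubstituted phenyl at this position, or about a phenyl ring carrying an amine or a carboxylic acid.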